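The source may hold more compounds than are shown below. What is called first, only, known or untested is meant among the compounds shown, and "the series" means these compounds.

In an ADME assay on MT4 cells (Homo sapiens) for cytotoxicity, read by MTT assay (on this read-out higher numbers stand for lower toxicity in this test and lower numbers for higher toxicity in this test), compound 1 (`O=C(CSc1nncnc1-c1ccccc1Cl)Nc1ccccc1`) gives 127000 nM and compound 2 (`Cc1ccc(NC(=O)CSc2nncnc2-c2ccccc2Cl)c(Br)c1`) gives 45000 nM as the lower of the two numbers. Among the measured compounds shown here, the only measured step (a 2.8-fold lower number from compound 1 to compound 2 (0.45 log units; beyond the scatter)) is modest but beyond the scatter, and it comes with 2-bromo-4-methylphenyl in place of phenyl on an amide-type nitrogen.

Compound 3 (`O=C(CSc1nncnc1-c1ccccc1Cl)Nc1ccccc1F`) has not been measured yet. It carries 2-fluorophenyl in place of 2-bromo-4-methylphenyl on an amide-type nitrogen. For the measured compounds named here, that single measured step is the only guide, so the expectation is a loose one. The entering group is again a phenyl, with fluorine as its only addition, so compound 3 is expected to move back towards compound 1 at 127000 nM without necessarily reaching it. A modest step is therefore expected in this assay (a 2.1-fold higher number from compound 2 to compound 3 (0.32 log units; beyond the scatter)) towards a higher number, which would mean lower toxicity in this test. For compound 3 the estimate is 95000 nM (expected range 40000 nM to 200000 nM).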

Compound 3, half-maximal cytotoxic concentration: 98000 nM
Estimate against measurement, compound 3: 1.0-fold (0.01 log units) below; low and high end bracket the measured number.
By their numbers in this assay, from the lowest: compound 2; then compounds 3 and 1 (each within the scatter of the next).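

In this assay, among the compounds shown here, the fluoro in place of hydrogen on an aromatic carbon is the first change on this ring that can be read as a single addition, and a 1.3-fold lower number from compound 1 to compound 3 (0.11 log units; within the scatter) leaves compound 3 and compound 1 within the scatter of each other. The other step, a 2.2-fold higher number from compound 2 to compound 3 (0.34 log units; beyond the scatter), shows that the lower number of compound 2 does not come with every substituted phenyl on this amide-type nitrogen: among these three compounds, only the 2-bromo-4-methylphenyl group stands apart, while a ring with a single fluoro does not. No measurement of any property of these groups is available to account for this difference.

As far as these compounds go, compound 2 carries its bromine and its methyl together, so the share of each in the step remains unknown, and 2-bromophenyl and 4-methylphenyl groups would be needed to separate them. All three compounds also carry a plain or halogen-bearing phenyl on this nitrogen, so they leave open how the number would respond to a carboxylic acid or an amine on that ring.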